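The source may report more compounds than this note shows. Statements on the series, on what has been measured and on what is new or still open speak of the compounds shown alone.

The measured compounds:
compound 1, `Cc1nc(S(C)(=O)=O)ccc1Oc1ncnc(OC2CCN(C(=O)OC(C)(C)C#N)CC2)c1F`, 1320 nM
compound 2, `Cc1nc(S(C)(=O)=O)ccc1Oc1ncnc(OC2CCN(C(=O)O[C@@H](C)CF)CC2)c1F`, 1680 nM

Both numbers come from a functional assay on isolated protein for inhibition of Glucose-dependent insulinotropic receptor (Rattus norvegicus), read by HTRF and cAMP accumulation; a higher number here means that more compound is needed for the effect, a lower number that less compound is needed. On the two numbers shown, compound 1 cannot be set apart from its only neighbour, since the gap is within the scatter: a 1.3-fold higher number from compound 1 to compound 2 (0.10 log units; within the scatter).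

Compound 3, `Cc1nc(S(C)(=O)=O)ccc1Oc1ncnc(OC2CCN(C(=O)OC3(C(F)(F)F)CCC3)CC2)c1F`, has not yet been measured in this assay. It differs from compound 1 in one place: 1-(trifluoromethyl)cyclobutyl in place of 1-cyano-1-methylethyl on an oxygen next to a carbonyl group. The group that leaves is an open chain carrying a nitrile; the group that enters is a four-membered non-aromatic ring of carbon only carrying a trifluoromethyl.

Among the measured compounds shown here, only one measured step bears on this position, the one in which the same 1-cyano-1-methylethyl gave way to 1-(fluoromethyl)ethyl: a 1.3-fold higher number from compound 1 to compound 2 (0.10 log units; within the scatter). That step stayed within the scatter, so the data give no direction for a change at this oxygen, and no step beyond the scatter is expected either way. For compound 3 the expected step is a 1.1-fold higher number from compound 1 to compound 3 (0.06 log units; within the scatter). The estimated value for compound 3 in this assay is 1500 nM, with a range from 500 nM to 4500 nM.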

Compound 3, half-maximal effective concentration: 63.3 nM
For compound 3 the middle estimate is 24-fold (1.37 log units) above the measured one; measured number outside the range, below it.
By their numbers in this assay, from the lowest: compound 3; then compounds 1 and 2 (each within the scatter of the next).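

In this assay the place on an oxygen next to a carbonyl group turns out to be far from indifferent, as the earlier pair had suggested: 1-(trifluoromethyl)cyclobutyl gives a 21-fold lower number from compound 1 to compound 3 (1.32 log units; beyond the scatter), and against the other open-chain group it gives a 27-fold lower number from compound 2 to compound 3 (1.42 log units; beyond the scatter). Among the compounds shown here, the small step among the open-chain groups, a 1.3-fold higher number from compound 1 to compound 2 (0.10 log units; within the scatter), therefore did not show how far this place can move the number; the two groups without a ring stay together, and the one group with a ring stands well apart from both. No measurement at hand accounts for this gap.

The change from compound 1 to compound 3 brings in the four-membered ring and the trifluoromethyl together, removes the nitrile and adds heavy atoms, so the compounds shown cannot say which of these differences goes with the large step. As far as these compounds go, a plain cyclobutyl, a 1-methylcyclobutyl or a 1-(trifluoromethyl)ethyl at this oxygen would separate the ring from the trifluoromethyl, and whether a cyclopentyl would hold the same low number also remains open.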